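The source may report more compounds than this note shows. Statements on the series, on what has been measured and on what is new or still open speak of the compounds shown alone.

Measured in an ADME assay on L02 cells (Homo sapiens) for inhibition, read by CCK-8 assay, with a stated time of 48 h; a higher number here means a weaker inhibitor of growth, a lower number a stronger inhibitor of growth:
- compound 1 `Cc1ccccc1Nc1nc(Nc2cccnc2)ncc1Cl`: 22900 nM
- compound 2 `Cc1ccccc1Nc1nc(NC2CCCCC2)ncc1Cl`: > 100000 nM

Compound 2 is reported only as a limit, > 100000 nM. Compound 3 `Cc1ccccc1Nc1nc(Nc2ccccc2)ncc1Cl` has phenyl in place of cyclohexyl on a nitrogen on an aromatic ring. Among the compounds with values here, the one measured step, an at least 4.3-fold higher number from compound 1 to compound 2 (0.64 log units; beyond the scatter), bears on this change when read in reverse, as an aromatic ring returns to that place. A step of at least similar size toward a lower number is therefore expected in this assay. The expected step is an at least 3.3-fold lower number from compound 2 to compound 3 (0.52 log units; beyond the scatter). For compound 3 the estimated value is 30000 nM, with an expected range of 10000 nM to 80000 nM.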

Compound 3, concentration for 50% growth inhibition: > 100000 nM
Compound 3 was reported as a limit (the forecaster's own chance of this, stated with the estimate: 15%); at least 3.3-fold (0.52 log units) between middle value and limit.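

Phenyl in place of pyridin-3-yl gives an at least 4.3-fold higher number from compound 1 to compound 3 (0.64 log units; beyond the scatter), so an aromatic ring on this nitrogen is not enough to keep the value of compound 1; here the pyridin-3-yl group goes with the only measured number. Compound 3 is reported only as a limit, > 100000 nM, and its step from compound 2 cannot be read, since both are limits. Only compound 1 stands clear of that limit: the limit of > 100000 nM in this assay, at which 2 of the 3 values shown sit.

Still open, going by these compounds, is whether an amine or a carboxylic acid on the phenyl ring would bring the value back within range. On these data alone, how far compound 2 and compound 3 lie beyond the limit also remains unknown.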